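A few compounds are considered here, and "the series" means these few. Any claim that something is new, unique, unknown or untested is made for them only; others in the source may bear on it.

Within the data shown here, in an ADME assay on microsomes from liver (Mus musculus) for metabolic stability (a higher number here means faster removal of the compound, a lower number slower removal), compound 1 `O=C(Nc1ccc(Cl)cc1)C(=O)N1CCC(c2ccnc3ccc(F)cc23)CC1` stands at 97 mL.min-1.g-1 and compound 2 `O=C(Nc1ccc(Cl)cc1)C(=O)N1CC[C@H](c2ccnc3ccc(F)cc23)[C@@H](O)C1` at 17 mL.min-1.g-1 as the lower of the two numbers so far. Among the measured compounds shown here, the one measured step is a 5.7-fold lower number from compound 1 to compound 2 (0.76 log units; beyond the scatter) for hydroxy in place of hydrogen on a saturated ring carbon, and it does not address configuration. For compound 3 `O=C(Nc1ccc(Cl)cc1)C(=O)N1CC[C@@H](c2ccnc3ccc(F)cc23)[C@H](O)C1` the change is this: the two compounds have the same atoms and bonds and differ only in configuration as drawn: 2 of 2 stereo elements differ (all stereocentres are inverted: mirror images); a stereocentre at a saturated ring carbon is drawn R in compound 2 and S in compound 3; a stereocentre at a saturated ring carbon is drawn R in compound 2 and S in compound 3. For the measured compounds named here, no measured pair of mirror images exists, so no step beyond the scatter is expected, and no direction can be assigned. Compound 3 is estimated at 22 mL.min-1.g-1 in this assay with an expected range of 9 mL.min-1.g-1 to 55 mL.min-1.g-1. The expected step is a 1.3-fold higher number from compound 2 to compound 3 (0.11 log units; within the scatter).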

Compound 3, intrinsic clearance in microsomes: 18 mL.min-1.g-1
Compound 3: the middle estimate sits 1.2-fold (0.09 log units) above what was measured; measured number inside the range.
By their numbers in this assay, from the lowest: compounds 2 and 3 (each within the scatter of the next); then compound 1.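

In this assay, inverting both stereocentres gives a 1.1-fold higher number from compound 2 to compound 3 (0.02 log units; within the scatter), so the mirror-image pair is not separated by this read-out. Configuration is the sole variable in this comparison: the fact that compounds 2 and 3 differ only in the configuration as drawn. The lower number with hydroxy in place of hydrogen on a saturated ring carbon is now seen in both mirror-image forms, with a 5.4-fold lower number from compound 1 to compound 3 (0.73 log units; beyond the scatter) alongside a 5.7-fold lower number from compound 1 to compound 2 (0.76 log units; beyond the scatter).

Open, going by these compounds, is whether the diastereomers of compounds 2 and 3 share this standing. Also open, on these data alone, is whether a methoxy or an amine on that ring carbon would give a comparable number.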